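The source may report more compounds than this note shows. Statements on the series, on what has been measured and on what is new or still open speak of the compounds shown alone.

Three compounds have been measured in a functional assay on A549 cells (Homo sapiens) for cytotoxicity, read by MTT assay, with a stated time of 4 days; on this read-out higher numbers stand for weaker inhibition and lower numbers for stronger inhibition:

Compound 1, `C/C=C/C(=O)OCC1=C[C@@H](O)CCC1=O`: 16700 nM
Compound 2, `C/C=C/C(=O)OCC1=C[C@H](O)[C@@H](c2ccccc2)CC1=O`: 1300 nM
Compound 3, `C/C=C/C(=O)OCC1=C[C@H](O)[C@H](c2ccccc2)CC1=O`: 8000 nM

Compound 2 shows the lowest of the three numbers. Its nearest neighbour is compound 3, with a 6.2-fold higher number from compound 2 to compound 3 (0.79 log units; beyond the scatter); these two compounds share all atoms and bonds, and the step rests only on (the fact that compounds 2 and 3 differ only in the configuration as drawn). Compound 1, which carries no substituent on the saturated ring carbon, stands furthest from compound 2, and its value in this assay is the highest of the three.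

The unmeasured compound 4, `C/C=C/C(=O)OCC1=C[C@H](O)[C@@H](C(C)C)CC1=O`, departs from compound 2 by isopropyl in place of phenyl on a saturated ring carbon. Within the data shown here, no measured step replaces the phenyl group by another substituent, so the only guidance is indirect: the step from compound 2 to compound 3 shows how much a change at this saturated ring carbon can move the number, and compound 1, lacking the group, gives a clearly higher value than compound 2. An isopropyl group is a different kind of substituent from phenyl, and the data say nothing about such an exchange. A moderate rise beyond the scatter is therefore expected, a 2.7-fold higher number from compound 2 to compound 4 (0.43 log units; beyond the scatter), with wide uncertainty. Compound 4 is estimated to give 3500 nM in this assay, in the range 1000 nM to 12000 nM.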

Compound 4, half-maximal inhibitory concentration: 14000 nM
For compound 4 the middle estimate is 4.0-fold (0.60 log units) below the measured one; measured number outside the range, above it.
By their numbers in this assay, from the lowest: compound 2; then compounds 3, 4 and 1 (each within the scatter of the next, the first and the last beyond it).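

In this assay, the position proves sensitive to the identity of the group as well as to its configuration: isopropyl in place of phenyl on the saturated ring carbon gives an 11-fold higher number from compound 2 to compound 4 (1.03 log units; beyond the scatter), a large change. Compound 4 at 14000 nM and compound 1, which has no substituent on that carbon, at 16700 nM lie within the scatter of each other, so in this assay isopropyl cannot be told apart from the absence of the group. Among these compounds, the lowest number therefore goes with phenyl in one drawn configuration only, and phenyl by itself does not secure it, as the other configuration gives a 6.2-fold higher number from compound 2 to compound 3 (0.79 log units; beyond the scatter) here.

The compounds shown leave open whether a pyridine ring, a benzyl group or a phenyl ring carrying a methoxy group or a fluorine atom on this carbon would keep a number near that of compound 2, and whether a methyl group or a cyclohexyl ring would behave like isopropyl. Nothing at hand bears on what lies behind the exchange of phenyl for isopropyl.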